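A few compounds are considered here, and "the series" means these few. Any claim that something is new, unique, unknown or untested is made for them only; others in the source may bear on it.

Values in a functional assay on Caco-2 cells (Homo sapiens) for inhibition, read by sulforhodamine B assay, with a stated time of 48 h; on this read-out lower numbers stand for stronger inhibition and higher numbers for weaker inhibition:
- compound 1 `CCO[C@H]1C[C@@H](c2coc3ccccc3c2=O)N(c2ccccc2)O1`: > 60000 nM (a limit)
- compound 2 `CCO[C@H]1C[C@@H](c2coc3ccc(F)cc3c2=O)N(c2ccccc2)O1`: > 60000 nM (a limit)
- compound 3 `O=c1c([C@@H]2C[C@H](c3ccccc3)ON2c2ccccc2)coc2ccc(F)cc12`: 60000 nM

Compound 2 has no number to start from, as its > 60000 nM is a limit. Within the data shown here, the series so far is defined by the limit of > 60000 nM in this assay, at which 2 of the 3 values shown sit.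

Compound 4 `CCO[C@H]1C[C@@H](c2coc3ccc(C)cc3c2=O)N(c2ccccc2)O1` differs from compound 2 by methyl in place of fluoro on an aromatic carbon of a six-membered aromatic ring of carbon only.

Among the measured compounds shown here, two measured steps bear on this change. The closer is a step that the two limits leave unreadable from compound 1 to compound 2, which also swaps a group on an aromatic carbon. The other is a number no higher from compound 2 to compound 3 (the limit leaves the size open), a change on a saturated ring carbon. Neither has a readable size, so neither gives a direction or a magnitude to carry over. No step beyond the scatter is therefore expected in this assay, and a further report as a limit is quite likely.

The estimated step is a number no higher from compound 2 to compound 4 (the limit leaves the size open).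

For compound 4 the estimate is 60000 nM, with an expected range of 25000 nM to 100000 nM.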

Compound 4, half-maximal inhibitory concentration: 31000 nM
Beside the measured number, compound 4's estimate is 1.9-fold (0.29 log units) above it, and the stated range covers the measured number.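

In this assay compound 4 gives 31000 nM, the first number rather than a limit among the ethoxy compounds shown, so this aromatic carbon can carry a change that registers on the read-out. Methyl in place of fluoro reads as an at least 1.9-fold lower number from compound 2 to compound 4 (0.28 log units; that floor lies within the scatter) and methyl in place of hydrogen reads as an at least 1.9-fold lower number from compound 1 to compound 4 (0.28 log units; that floor lies within the scatter) in the same assay. From the compounds shown here alone, both floors lie within the scatter, and the true sizes stay open, since the starting values are limits: the limit of > 60000 nM in this assay, at which 2 of the 4 values shown sit.

Whether methyl is a real gain at this carbon therefore remains unsettled, and the step from fluoro's parent hydrogen to fluoro cannot be read. Also open, going by these compounds, is how a methoxy, an amine or a longer chain at this aromatic carbon would read in this assay.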